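From 4-hydroxybenzyl to 2-hydroxybenzyl on the shared core

The compounds below may be only part of what the source reports. "The series", "measured", "known", "first", "only" and "open" are said of these compounds alone.

In a functional assay on NCI-H1299 cells (Homo sapiens) for antiproliferative activity, read by fluorescence and resazurin assay, with a stated time of 48 h (on this read-out lower numbers stand for stronger inhibition and higher numbers for weaker inhibition), compound 3 (`COc1ccc(-c2cn(Cc3ccc(O)cc3)cc2-c2ccc(OC)cc2)cc1`) gives 20500 nM, within the scatter of compound 1 (`COc1ccc(Cn2cc(-c3ccc(O)cc3)c(-c3ccc(O)cc3)c2)cc1`) at 37300 nM and of compound 2 (`COc1ccccc1Cn1cc(-c2ccc(O)cc2)c(-c2ccc(O)cc2)c1`) at 23100 nM. Compound 4 (`COc1ccc(-c2cn(Cc3ccccc3O)cc2-c2ccc(OC)cc2)cc1`) has 2-hydroxyphenyl in place of 4-hydroxyphenyl on a saturated chain carbon bound to an aromatic nitrogen. Within the data shown here, the only measured step that bears on this is the matching change among methoxyphenyl groups on that chain carbon, a 1.6-fold lower number from compound 1 to compound 2 (0.21 log units; within the scatter), which lies within the scatter. It is an indirect guide, since the group there is methoxyphenyl and not hydroxyphenyl. No change beyond the scatter is therefore expected in this assay. The expected step is a 1.2-fold lower number from compound 3 to compound 4 (0.08 log units; within the scatter). Compound 4 is estimated at 17000 nM, with an expected range of 8000 nM to 36000 nM.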

Compound 4, half-maximal inhibitory concentration: 20800 nM
Compound 4: middle estimate off by 1.2-fold (0.09 log units), on the low side; the range from low to high includes it.
By their numbers in this assay, from the lowest: compounds 3, 4, 2 and 1 (each within the scatter of the next).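

In this assay, the change to 2-hydroxyphenyl on a saturated chain carbon bound to an aromatic nitrogen gives a 1.0-fold higher number from compound 3 to compound 4 (0.01 log units; within the scatter). Among these compounds, this is the first direct reading for hydroxyphenyl at this place, and like a 1.6-fold lower number from compound 1 to compound 2 (0.21 log units; within the scatter), read on methoxyphenyl, it stays within the scatter. Nothing available accounts for this result.

The compounds shown leave open whether an amine or a carboxylic acid in place of the hydroxy group on that benzyl, or a longer chain in place of its saturated chain carbon, would move the number beyond the scatter.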